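Compound 4: Cyano Replaces Chloro on the Benzyl Ring

The source may report more compounds than this note shows. Statements on the series, on what has been measured and on what is new or still open speak of the compounds shown alone.

Of the compounds shown here, three built on one shared core have been measured in a functional assay on the whole organism (B cells) with Mus musculus as the target; a higher number here means a larger maximal response, a lower number a smaller maximal response. Compound 1, `Nc1nc(O)c2c(n1)n(C1OC(CO)[C@@H](O)[C@H]1O)c(=O)n2C/C=C/c1ccccc1`, gives 73%. Compound 2, `COc1ccc(Cn2c(=O)n(C3OC(CO)[C@@H](O)[C@H]3O)c3nc(N)nc(O)c32)cc1`, gives 44%. Compound 3, `Nc1nc(O)c2c(n1)n(C1OC(CO)[C@@H](O)[C@H]1O)c(=O)n2Cc1ccc(Cl)cc1`, gives 15% and stands lowest of the three, as a number 29 percentage points lower from compound 2 to compound 3 (beyond the scatter) and a number 58 percentage points lower from compound 1 to compound 3 (beyond the scatter) show. Compound 4, `N#Cc1ccc(Cn2c(=O)n(C3OC(CO)[C@@H](O)[C@H]3O)c3nc(N)nc(O)c32)cc1`, differs from compound 3 by cyano in place of chloro on an aromatic carbon.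

Among the compounds with values here, no measured step introduces a cyano group, so only the exchanges at the same aromatic carbon bear on this one. There, a number 29 percentage points lower from compound 2 to compound 3 (beyond the scatter) was modest, and a number 29 percentage points lower from compound 1 to compound 2 (beyond the scatter) was of the same size, while a number 58 percentage points lower from compound 1 to compound 3 (beyond the scatter) combined both. Compound 3 already sits near the bottom of the measured range, so room for a further fall is small, and nothing measured points to a rise of any size. The expected step is therefore a number 5 percentage points higher from compound 3 to compound 4 (within the scatter), most likely within the scatter. For compound 4 the estimate in this assay is 20%, with an expected range from 5% to 45%.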

Compound 4, largest response reached (reported as maximal response), in percent of the reference or control that the assay uses: 50%
Beside the measured number, compound 4's estimate is 30 percentage points below it, and the stated range ends below it.
By their numbers in this assay, from the lowest: compound 3; then compounds 2 and 4 (each within the scatter of the next); then compound 1.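

In this assay the exchange of chloro for cyano gives a number 35 percentage points higher from compound 3 to compound 4 (beyond the scatter) and so shows that the low number of compound 3 is not shared by every group on this aromatic carbon. Cyano and methoxy cannot be told apart here, with a number 6 percentage points higher from compound 2 to compound 4 (within the scatter), which leaves chloro alone among the three groups at the low end. The benzyl compounds still do not reach the 2-phenylethenyl compound, with a number 23 percentage points lower from compound 1 to compound 4 (beyond the scatter) as the closest printed comparison for the cyano group.

No measurement shown here explains why chloro differs from cyano and methoxy. From the compounds shown here alone, whether an amine, a carboxylic acid or a fluoro group on this aromatic carbon would give a number nearer that of compound 3 or that of compound 4 stays open.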